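Chloro in place of trifluoromethyl: a second instance expected

The compounds below may be only part of what the source reports. "The series", "measured", "known", "first", "only" and "open" are said of these compounds alone.

Measured in a functional assay on NCI-H322M cells (Homo sapiens) for inhibition, read by sulforhodamine B assay, with a stated time of 48 h, tested at 1 uM; on this read-out lower numbers stand for a stronger effect and higher numbers for a weaker effect at the one concentration tested:
compound 1 `O=C(Nc1cccc(-n2cc(-c3ccncc3)c(-c3cc(O)cc(Cl)c3)n2)c1)Nc1ccc(Cl)c(C(F)(F)F)c1` gives 93%
compound 2 `O=C(Nc1cccc(-n2cc(-c3ccncc3)c(-c3cc(O)cc(Cl)c3)n2)c1)Nc1ccc(Cl)c(Cl)c1` gives 59%
compound 3 `COc1cc(Cl)cc(-c2nn(-c3cccc(NC(=O)Nc4ccc(Cl)c(C(F)(F)F)c4)c3)cc2-c2ccncc2)c1` gives 89%

For the measured compounds named here, the one change that recurs is chloro in place of trifluoromethyl on an aromatic carbon. Between the two measured compounds carrying it, the result is a number 34 percentage points lower from compound 1 to compound 2 (beyond the scatter), the only step in the set that clears the scatter. Compound 3 differs from compound 1 by methyl in place of hydrogen on an oxygen on an aromatic ring, and this gives a number 4 percentage points lower from compound 1 to compound 3 (within the scatter), so compound 1 and compound 3 are treated as equivalent starting points.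

Compound 4 `COc1cc(Cl)cc(-c2nn(-c3cccc(NC(=O)Nc4ccc(Cl)c(Cl)c4)c3)cc2-c2ccncc2)c1` has not been measured. It differs from compound 3 by chloro in place of trifluoromethyl on an aromatic carbon, the same change, at the same place, as that from compound 1 to compound 2. The change has been seen only once, so the expectation rests on a single precedent and the range is kept wide.

In this assay, going by the values given here, the step from compound 3 to compound 4 is expected to be a number 34 percentage points lower from compound 3 to compound 4 (beyond the scatter), because a number 34 percentage points lower from compound 1 to compound 2 (beyond the scatter) is the only precedent and compound 3 starts from a value close to that of compound 1. Compound 4 is therefore estimated at 55%, expected to fall between 35% and 78%.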

Compound 4, a percentage reported as activity, at one concentration (the size of the read-out at that concentration, not a potency): 88%
Compound 4: the middle estimate sits 33 percentage points below what was measured, outside the stated range (above it).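

In this assay, chloro in place of trifluoromethyl on an aromatic carbon does not carry from the core of compound 1 to the core of compound 3, where the result is a number 1 percentage points lower from compound 3 to compound 4 (within the scatter), and the two outcomes differ: the same change on two cores in this assay, a number 34 percentage points lower (beyond the scatter) from compound 1 to compound 2 and a number 1 percentage points lower (within the scatter) from compound 3 to compound 4, 33 percentage points apart, beyond the scatter of two such steps

Read along the other edge of the same four compounds, methyl in place of hydrogen on an oxygen on an aromatic ring gives a number 29 percentage points higher from compound 2 to compound 4 (beyond the scatter), and this too differs from its earlier counterpart: the same change on two cores in this assay, a number 4 percentage points lower (within the scatter) from compound 1 to compound 3 and a number 29 percentage points higher (beyond the scatter) from compound 2 to compound 4, 33 percentage points apart, beyond the scatter of two such steps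

The two changes therefore do not add up independently here, with compound 2 alone standing apart from the other three, but one such set of four compounds, each read at a single concentration, shows neither why this is so nor whether it extends beyond these compounds.

The compounds shown leave open whether the step with chloro requires the free hydroxy group, or would also appear with an amine or a longer alkoxy chain in that place. They also leave open whether bromo or a nitrile in place of trifluoromethyl would follow chloro on either core.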